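The compounds below may be only part of what the source reports. "The series", "measured", "known", "first", "only" and "open" are said of these compounds alone.

Measured so far in a functional assay on the whole organism with Mus musculus as the target, in the maximal electroshock model; on this read-out higher numbers stand for an effect only at larger amounts of compound and lower numbers for an effect already at smaller amounts:
compound 1 `Cc1nn2cc(-c3ccccc3)nc2cc1Cc1ccccc1` — 105 mg/kg
compound 2 `Cc1nn2c(-c3ccccc3)nnc2cc1Cc1ccccc1` — 108 mg/kg

Compound 2 holds the highest of the two numbers, but compound 1 sits within the scatter of it, so the two values show no difference. Within the data shown here, no step between measured compounds bears on the next change. Compound 3 `Cc1nn2cnnc2cc1Cc1ccccc1` differs from compound 2 by hydrogen in place of phenyl on an aromatic carbon. Without a measured precedent for this change, the expected step of a 1.7-fold higher number from compound 2 to compound 3 (0.22 log units; within the scatter) is a modest move toward a larger dose, not firmly beyond the scatter. In this assay compound 3 is estimated at 180 mg/kg, with a range from 80 mg/kg to 400 mg/kg.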

Compound 3, dose for half-maximal effect: 9.5 mg/kg
Compound 3: middle estimate off by 19-fold (1.28 log units), on the high side; measured number outside the range, below it.
By their numbers in this assay, from the lowest: compound 3; then compounds 1 and 2 (each within the scatter of the next).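

In this assay, hydrogen in place of phenyl on this aromatic carbon, between two ring nitrogen atoms, gives an 11-fold lower number from compound 2 to compound 3 (1.06 log units; beyond the scatter) on an otherwise unchanged structure. This position is therefore sensitive to its substituent, and the phenyl is not needed for an effect at small doses. No available data explain the size of this step.

Open, on these data alone, is whether a methyl, a methoxy or an amine on this carbon keeps the low dose. Also open, as far as these compounds go, is whether the same change on the core of compound 1 gives a step of similar size.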